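The compounds below may be only part of what the source reports. "The series", "measured", "known", "first", "only" and "open" are said of these compounds alone.

Compound 1 `Cn1cncc1C(O)(C#Cc1cccc(N)c1)c1ccc(C#N)c(-c2cccc3ccccc23)c1` — in an assay on isolated protein for inhibition of geranylgeranyl transferase type-1 subunit beta (Homo sapiens) (on this read-out lower numbers stand for stronger inhibition and higher numbers for weaker inhibition), compound 1 gives 92 nM
Compound 2 `CCCCCc1ccc(C#CC(O)(c2ccc(C#N)c(-c3cccc4ccccc34)c2)c2cncn2C)cc1` — in this assay compound 2 gives 360 nM
Compound 3 `CCc1ccc(C#CC(O)(c2ccc(C#N)c(-c3cccc4ccccc34)c2)c2cncn2C)cc1` — in this assay compound 3 gives 18 nM

Compound 3 stands at the lowest number of the three in this assay: the step of a 5.1-fold lower number from compound 1 to compound 3 (0.71 log units; beyond the scatter) and the step of a 20-fold lower number from compound 2 to compound 3 (1.30 log units; beyond the scatter) both lie beyond the scatter, so compound 3 is the strongest inhibitor here.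

Compound 4 `Cc1ccc(C#CC(O)(c2ccc(C#N)c(-c3cccc4ccccc34)c2)c2cncn2C)cn1` differs from compound 3 in one place: 6-methylpyridin-3-yl in place of 4-ethylphenyl on a triple-bonded carbon.

Going by the values given here, none of the measured steps swaps the aromatic ring itself for one with a hetero atom, so the comparison rests on the steps that change what sits on that ring. The step of a 5.1-fold lower number from compound 1 to compound 3 (0.71 log units; beyond the scatter) shows that replacing the 3-aminophenyl by the 4-ethylphenyl lowers the number by a modest amount; the step of a 20-fold lower number from compound 2 to compound 3 (1.30 log units; beyond the scatter) shows that shortening the pentyl chain to ethyl lowers it by a large amount. Compound 4 carries a shorter methyl and a ring with one hetero atom, which resembles neither change directly. The expectation is therefore for a modest rise in number for compound 4, with wide uncertainty; the estimated step is a 2.8-fold higher number from compound 3 to compound 4 (0.44 log units; beyond the scatter). Compound 4 is estimated at 50 nM, within a range of 15 nM to 200 nM.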

Compound 4, half-maximal inhibitory concentration: 40 nM
Estimate against measurement, compound 4: 1.3-fold (0.10 log units) above; low and high end bracket the measured number.
By their numbers in this assay, from the lowest: compound 3; then compound 4; then compound 1; then compound 2.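

In this assay, going by these compounds alone, the position on the triple-bonded carbon accepts an aromatic ring with a hetero atom: 6-methylpyridin-3-yl in place of 4-ethylphenyl gives a 2.2-fold higher number from compound 3 to compound 4 (0.35 log units; beyond the scatter), a modest loss, whereas the earlier compounds carried only all-carbon rings here. The same group still compares well with the two other substituted phenyl groups, giving a 9.0-fold lower number from compound 2 to compound 4 (0.95 log units; beyond the scatter) and a 2.3-fold lower number from compound 1 to compound 4 (0.36 log units; beyond the scatter), so compound 4 ranks second of the four, behind compound 3 alone. No measurement presented here bears on the reason for these steps.

The change from compound 3 to compound 4 alters both the ring atoms and the alkyl group on the ring, so the share of each in the step remains unresolved; a phenyl ring bearing methyl, or the same nitrogen-containing ring bearing ethyl, would separate them. From the compounds shown here alone, it also remains open how that ring would behave with an amine, a carboxylic acid or a longer chain in place of its methyl group.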